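Moving a Methyl Around a Phenyl Ring

The source may report more compounds than this note shows. Statements on the series, on what has been measured and on what is new or still open speak of the compounds shown alone.

Three compounds share one core and differ only in one aryl group. In an assay on isolated protein for inhibition of DNA topoisomerase 1 (Homo sapiens), tested at 100 uM (a lower number here means a weaker effect, a higher number a stronger effect of the compound at the concentration tested), compound 1 `Cc1cccc(-c2cc(-c3ccc(Cl)o3)cc(-c3ccsc3)n2)c1` gives 7.5%, compound 2 `Clc1ccc(-c2cc(-c3ccc(Cl)o3)cc(-c3ccsc3)n2)cc1` gives 29.8%, and compound 3 `Cc1ccc(-c2cc(-c3ccc(Cl)o3)cc(-c3ccsc3)n2)cc1` gives 2.6%, the lowest of the three numbers, though its gap to compound 1 lies within the scatter; only compound 2 stands clearly apart, as a number 27.2 percentage points lower from compound 2 to compound 3 (beyond the scatter) shows. Compound 4 `Cc1ccccc1-c1cc(-c2ccc(Cl)o2)cc(-c2ccsc2)n1` differs from compound 3 by 2-methylphenyl in place of 4-methylphenyl on an aromatic carbon. The measured step that bears on this is a number 4.9 percentage points lower from compound 1 to compound 3 (within the scatter), which also moved a methyl around the phenyl ring and stayed within the scatter; a number 22.3 percentage points higher from compound 1 to compound 2 (beyond the scatter) concerns a chloro and is less telling. For compound 4 a step within the scatter is therefore expected, a number 3.4 percentage points higher from compound 3 to compound 4 (within the scatter). In this assay compound 4 is estimated to give 6%, within 0% to 18%.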

Compound 4, a percentage reported as inhibition, at one concentration (the size of the read-out at that concentration, not a potency): 6.7%
Beside the measured number, compound 4's estimate is 0.7 percentage points below it, within the range that was stated.
By their numbers in this assay, from the lowest: compounds 3, 4 and 1 (each within the scatter of the next); then compound 2.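

With the 2-methylphenyl group, all three placements of the methyl on this phenyl ring can be compared in this assay, and the placement makes no readable difference: the change gives a number 4.1 percentage points higher from compound 3 to compound 4 (within the scatter), and a number 0.8 percentage points lower from compound 1 to compound 4 (within the scatter). The separation from the chloro compound also holds for this third placement, at a number 23.1 percentage points lower from compound 2 to compound 4 (beyond the scatter). No evidence available here accounts for these numbers. On these data alone, it remains open whether the higher number of compound 2 is tied to the chloro group at that one placement, as a 2-chlorophenyl or 3-chlorophenyl group would show. A 4-methoxyphenyl or 4-aminophenyl group could also test how far this phenyl ring tolerates other substituents.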